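A side-chain swap on a shared core

The source may report more compounds than this note shows. Statements on the series, on what has been measured and on what is new or still open speak of the compounds shown alone.

In an ADME assay on L6 cells (Rattus norvegicus) for cytotoxicity, read by resazurin assay, with a stated time of 72 h (on this read-out lower numbers stand for stronger inhibition and higher numbers for weaker inhibition), compound 2 `CN(C)C12CC(OC(=O)CN3CCCC3)C(C(c3ccccc3)C1)C(c1ccccc1)C2` gives 32700 nM as its result, and compound 1 `NC1CC2(N3CCCC3)CC(c3ccccc3)C1C(c1ccccc1)C2` gives 38100 nM as its result, so these two sit within the scatter of each other. Compound 3 `CN1CCN(CC(=O)N2CCC3(N(C)C)CC(c4ccccc4)C2C(c2ccccc2)C3)CC1` reads 195000 nM and thus lies clearly higher than compound 2. In compound 4 `CN1CCN(CC(=O)NC2CC3(N(C)C)CC(c4ccccc4)C2C(c2ccccc2)C3)CC1`, (((4-methylpiperazin-1-yl)methyl)carbonyl)amino stands in place of (((pyrrolidin-1-yl)methyl)carbonyl)oxy on a saturated ring carbon (((4-methylpiperazin-1-yl)methyl)carbonyl)amino in place of (((pyrrolidin-1-yl)methyl)carbonyl)oxy on a saturated ring carbon while the shared core stays. Within the data shown here, no measured pair shows this change alone. Compound 3 also holds a 4-methylpiperazine ring and reads 195000 nM here, so a moderate rise in this assay is expected, toward weaker inhibition. The estimated change is a 2.6-fold higher number from compound 2 to compound 4 (0.41 log units; beyond the scatter) in size. For compound 4 the estimated value is 85000 nM within a range from 30000 nM to 220000 nM overall.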

Compound 4, half-maximal inhibitory concentration: 66200 nM
The estimate for compound 4 lay 1.3-fold (0.11 log units) above the measured number, and the stated range covers the measured number.
By their numbers in this assay, from the lowest: compounds 2, 1 and 4 (each within the scatter of the next, the first and the last beyond it); then compound 3.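

In this assay the swap on this saturated ring carbon gives a 2.0-fold higher number from compound 2 to compound 4 (0.31 log units; beyond the scatter), a modest move toward weaker inhibition and the first step measured at this position. The step changes the link and the ring together, with (((4-methylpiperazin-1-yl)methyl)carbonyl)amino entering and (((pyrrolidin-1-yl)methyl)carbonyl)oxy leaving, so it cannot be divided between them. No evidence at hand explains the shift.

Still open, as far as these compounds go, is how much of the step belongs to the link and how much to the ring. Also open, from the compounds shown here alone, is how a morpholine ring or a carboxylic acid on this carbon would read.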